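Compound 3 and the step from the imidazole to the pyrazole

The source may report more compounds than this note shows. Statements on the series, on what has been measured and on what is new or still open speak of the compounds shown alone.

Values in a physicochemical assay for solubility, read by LC-MS, in phosphate buffer, with a stated time of 24 h, at pH 7.4; a lower number here means a less soluble compound, a higher number a more soluble compound
- compound 1 `Cc1nccn1-c1cnc(NCc2c(F)ccc3c2CCO3)c2cn[nH]c(=O)c12` gives 7000 nM
- compound 2 `Cc1ncc(-c2cnc(NCc3c(F)ccc4c3CCO4)c3cn[nH]c(=O)c23)n1C` gives 15000 nM

Of the two measured compounds, compound 2 holds the higher number, at 15000 nM. The next change leads to compound 3 `Cc1cc(-c2cnc(NCc3c(F)ccc4c3CCO4)c3cn[nH]c(=O)c23)n(C)n1`, in which 1,3-dimethyl-1H-pyrazol-5-yl takes the place of 1,2-dimethyl-1H-imidazol-5-yl on an aromatic carbon (1,3-dimethyl-1H-pyrazol-5-yl in place of 1,2-dimethyl-1H-imidazol-5-yl on an aromatic carbon). The two have the same atoms, joined differently.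

Going by the values given here, only one measured step bears on this change, and only indirectly. It is a 2.1-fold higher number from compound 1 to compound 2 (0.33 log units; beyond the scatter), modest but beyond the scatter, and it also exchanges one group for another on that aromatic carbon. Among the compounds with values here, no pyrazolyl compound has been measured yet, so the direction remains uncertain. With compound 2 at the top of this short series, a modest downward step in this assay is the more likely outcome. The expected step is a 2.1-fold lower number from compound 2 to compound 3 (0.33 log units; beyond the scatter). For compound 3 the estimated value is 7000 nM, with an expected range from 2500 nM to 18000 nM.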

Compound 3, solubility: 1000 nM
The estimate for compound 3 lay 7.0-fold (0.85 log units) above the measured number; the measured number lies below the stated range.
By their numbers in this assay, from the lowest: compound 3; then compound 1; then compound 2.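

In this assay, the position on the aromatic carbon, para to a large group, proves sensitive to how the atoms of the five-membered ring are joined: with the heavy-atom, hydrogen-bond donor and acceptor counts unchanged, the exchange gives a 15-fold lower number from compound 2 to compound 3 (1.18 log units; beyond the scatter), so these counts do not settle the number here. The pyrazolyl group also falls short of the other imidazolyl group, with a 7.0-fold lower number from compound 1 to compound 3 (0.85 log units; beyond the scatter), which places compound 3 lowest of the three, and the step between the two imidazolyl groups, printed as modest, did not reveal a change of this size at the position. No measurement to hand accounts for the drop.

With a single pyrazolyl compound, the ring itself cannot be separated from the placement of its methyl groups, and another arrangement of the same pyrazole might read quite differently. As far as these compounds go, it also remains open whether an amine, such as a dimethylaminomethyl chain, or a carboxylic acid on the 1,3-dimethyl-1H-pyrazol-5-yl ring would recover the number seen for compound 2 at 15000 nM.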